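One Added Methyl on Compound 2

This account rests on a few compounds, and the source may have more. Where it says the series, first, only, none or still open, it means among the compounds named here.

Of the compounds shown here, two have been measured in an ADME assay on liver (Homo sapiens) for metabolic stability, read by LC-MS, using microsomes and NADPH; on this read-out higher numbers stand for a more stable compound and lower numbers for a less stable compound. Compound 1 (`CCN(Cc1ccc(OCCN2C(=O)CCC2=O)c(C)c1)C(CC(=O)O)c1ccc(Cl)cc1`) gives 100%, and compound 2 (`Cc1cc(CN(C)C(CC(=O)O)c2ccc(Cl)cc2)ccc1OCCn1c(=O)ccn(C)c1=O`) gives 76%, the lower of the two numbers, with a gap beyond the scatter. Compound 3 (`CCN(Cc1ccc(OCCn2c(=O)ccn(C)c2=O)c(C)c1)C(CC(=O)O)c1ccc(Cl)cc1`) differs from compound 2 by one change: methyl in place of hydrogen on a saturated chain carbon bound to an amine nitrogen. Among the measured compounds shown here, no measured step isolates this change, so a shift within the scatter, without a firm direction, is expected. The expected step is a number 2 percentage points higher from compound 2 to compound 3 (within the scatter). For compound 3 the estimated value is 78%, within a range of 62% to 93%.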

Compound 3, percent of the compound remaining: 46%
Beside the measured number, compound 3's estimate is 32 percentage points above it; measured number below the stated range.
By their numbers in this assay, from the lowest: compound 3; then compound 2; then compound 1.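

In this assay, methyl in place of hydrogen on a saturated chain carbon bound to an amine nitrogen, which also reads as methyl to ethyl, gives a number 30 percentage points lower from compound 2 to compound 3 (beyond the scatter), so this small change carries real weight in this pair. With the ethyl kept, exchanging the five-membered non-aromatic ring group for the six-membered aromatic one gives a number 54 percentage points lower from compound 1 to compound 3 (beyond the scatter), a larger step. Nothing at hand bears on the reason for either step. The compounds shown leave open whether the methyl to ethyl step has the same size with the five-membered ring group in place. They also leave open what a propyl or cyclopropyl group on that amine nitrogen would give.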